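The compounds below may be only part of what the source reports. "The series", "measured", "known", "first", "only" and "open" are said of these compounds alone.

Three compounds of the series carry a number in an assay on HeLa cells for displacement of a labelled ligand from adenosine receptor A3 (Homo sapiens), read by scintillation counting, with a stated time of 180 min, tested at 10 uM; on this read-out higher numbers stand for more inhibition at the one concentration tested (going by the name of the read-out) and lower numbers for less inhibition. Compound 1 `COCCNC(=O)c1cc2cccc(OC)c2oc1=O` gives 0%, the lowest of the three. Compound 2 `COc1cccc2cc(C(=O)NC3CCCCC3)c(=N)oc12` gives 16%, a number above compound 1 by a margin beyond the scatter. Compound 3 `COc1cccc2c1OC(C)(O)C(C(C)=O)=C2` gives 30%, the furthest from compound 1, again beyond the scatter. No pair among these three differs in one place only, so no single measured step is available to calibrate a change on the amide nitrogen.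

Compound 4 `COc1cccc2cc(C(=O)N[C@@H](CO)C(=O)O)c(=O)oc12` has not yet been measured in this assay. It differs from compound 1 by 1-carboxy-2-hydroxyethyl in place of 2-methoxyethyl on an amide-type nitrogen. Within the data shown here, with no measured step of this kind to lean on, the expected step is a number 5 percentage points higher from compound 1 to compound 4 (within the scatter), that is, none beyond the scatter or at most a small rise. Compound 4 is estimated at 5%, with a range from 0% to 20%. The reading of compound 1 at 0% leaves little room for a lower outcome.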

Compound 4, a percentage reported as inhibition, at one concentration (the size of the read-out at that concentration, not a potency): 3%
The estimate for compound 4 lay 2 percentage points above the measured number; the range from low to high includes it.
By their numbers in this assay, from the lowest: compounds 1 and 4 (each within the scatter of the next); then compound 2; then compound 3.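

In this assay, the amide-type nitrogen now has its first measured step: 1-carboxy-2-hydroxyethyl in place of 2-methoxyethyl gives a number 3 percentage points higher from compound 1 to compound 4 (within the scatter) on the shared core. This one exchange brings a larger side chain, more hydrogen-bond donors and acceptors and a defined stereocentre to this nitrogen, and the read-out at the one concentration tested does not separate the two compounds. Nothing on hand bears on why the two compounds read alike.

Since the step joins two low readings, it does not show whether any group on this nitrogen can raise the number. From the compounds shown here alone, a 2-aminoethyl or benzyl group here remains open, as does the mirror-image form of the 1-carboxy-2-hydroxyethyl group.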